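The compounds below may be only part of what the source reports. "The series", "measured", "known", "first", "only" and "open" are said of these compounds alone.

Measured compounds:
- compound 1, `COc1ccccc1-c1cc(COc2ccc3oc(=O)ccc3c2)on1`, "not determined" (no result reported) in a functional assay on HL-60 cells (Homo sapiens) for cytotoxicity, read by MTT assay, with a stated time of 48 h; a lower number here means a stronger inhibitor, a higher number a weaker inhibitor
- compound 2, `COc1ccc(-n2cc(COc3ccc4oc(=O)ccc4c3)nn2)cc1`, 46400 nM

Going by the values given here, compound 2 is the only compound here with a number in this assay; compound 1 carries no result there, so nothing can be said about how the two compare. Among the compounds with values here, on the single value shown, compound 2 is a weak inhibitor of these cells.

Compound 3, `O=c1ccc2cc(OCc3cn(-c4ccccc4[N+](=O)[O-])nn3)ccc2o1`, keeps the shared core and changes only the group on the aromatic nitrogen: 2-nitrophenyl in place of 4-methoxyphenyl on an aromatic nitrogen. Within the data shown here, no step between two measured compounds is available to guide this change, so the expectation must rest on compound 2 alone. With a group of comparable size swapped in, the step from compound 2 to compound 3 is expected to stay within the usual scatter of this assay, a 1.2-fold lower number from compound 2 to compound 3 (0.06 log units; within the scatter). Compound 3 is therefore estimated at 40000 nM, with a plausible range from 15000 nM to 120000 nM.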

Compound 3, half-maximal inhibitory concentration: 44600 nM
The estimate for compound 3 lay 1.1-fold (0.05 log units) below the measured number; the measured number falls inside the stated range.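

In this assay, putting 2-nitrophenyl in place of 4-methoxyphenyl on the aromatic nitrogen gives a 1.0-fold lower number from compound 2 to compound 3 (0.02 log units; within the scatter). A single number could not show whether this position responds to a new group at all; now two different substituted phenyl groups, carrying different substituents at different places on the ring, read alike here, and both compounds remain weak inhibitors of these cells. No measurement on hand explains this result.

The compounds shown leave open whether this sameness holds only for these two phenyl groups or extends further along this position. An unsubstituted phenyl ring, a phenyl ring carrying an amine or a carboxylic acid, or a longer alkyl chain in place of the ring could each test whether any group here moves the number beyond the scatter.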